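Swapping the ring on the imidazole nitrogen: benzyl for cyclohexyl

The source may hold more compounds than are shown below. What is called first, only, known or untested is meant among the compounds shown, and "the series" means these compounds.

Of the compounds shown here, two have a number so far. Compound 1 `Brc1ccc(-c2cn3ccnc3c(-c3ccc4ncn(C5CCCCC5)c4c3)n2)cc1` gives 1.73 in a physicochemical assay for lipophilicity, using the shake flask method, in phosphate buffer, measured as octanol-water partition, with a stated time of 85 min, at pH 7.4; a higher number here means a more lipophilic compound, a lower number a more polar compound. Compound 2 `c1cn2cc(-c3ccc4c(c3)ncn4C3CCCCC3)nc(-c3ccc4ncn(C5CCCCC5)c4c3)c2n1` gives 1.9 in this assay. The two values of compound 2 and compound 1 lie within the usual scatter of each other, so no ordering between them can be read from the numbers. Among the compounds with values here, no pair of measured compounds differs in just one place, so no single-point step is available to calibrate against.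

Compound 3 `c1ccc(Cn2cnc3ccc(-c4nc(-c5ccc6c(c5)ncn6C5CCCCC5)cn5ccnc45)cc32)cc1` differs from compound 2 in one place: benzyl in place of cyclohexyl on an aromatic nitrogen. Within the data shown here, nothing measured so far covers this exchange, so the expectation rests on the change itself and on the value of compound 2. For compound 3 the expectation in this assay is a modest step downward, a number 0.35 log units lower from compound 2 to compound 3 (beyond the scatter), larger than the scatter but not by much. Compound 3 is therefore estimated at 1.55, with a range from 1.1 to 2 in this assay, to be checked once the measurement is in hand.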

Compound 3, partition coefficient: 1.61
Compound 3: middle estimate off by 0.06 log units, on the low side; low and high end bracket the measured number.
By their numbers in this assay, from the lowest: compounds 3, 1 and 2 (each within the scatter of the next).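

Within the data shown here, the exchange on this aromatic nitrogen provides the first single-place step: in this assay, benzyl in place of cyclohexyl gives a number 0.29 log units lower from compound 2 to compound 3 (within the scatter). This position therefore takes a seven-carbon benzyl with an aromatic ring in place of a six-carbon cyclohexyl with a non-aromatic ring, and the step stays within the scatter, so this exchange shows no readable difference between compound 2 and compound 3. Nothing at hand offers an explanation for the size of this step.

As far as these compounds go, both groups in this exchange consist of carbon only, with no hydrogen-bond donors or acceptors and no net charge, so it remains open whether an amine or a carboxylic acid on a longer chain at this nitrogen would give a step beyond the scatter. From the compounds shown here alone, compound 3 also keeps a cyclohexyl on the other aromatic nitrogen, and whether benzyl in place of that group would give a similar step also remains open.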